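The source may hold more compounds than are shown below. What is called first, only, known or untested is meant among the compounds shown, and "the series" means these compounds.

Measured so far:
Compound 1, `Cc1nc(Nc2ccccc2)sc1C(=O)/C=C/c1ccc(Cl)cc1`. In a functional assay on Bel-7402 cells (Homo sapiens) for cytotoxicity, read by MTT assay (on this read-out lower numbers stand for stronger inhibition and higher numbers for weaker inhibition), compound 1 gives > 25000 nM, which is a limit of the assay, not a number.
Compound 2, `Cc1nc(Nc2ccc(Cl)cc2)sc1C(=O)/C=C/c1ccc(Cl)cc1`. Compound 2 gives > 25000 nM, again a limit.
Compound 3, `Cc1nc(Nc2ccc(Cl)c(Cl)c2)sc1C(=O)/C=C/c1ccc(Cl)cc1`. Compound 3 gives > 25000 nM, also a limit.

Compound 3 therefore stands only at the limit, as do the other two, because the limit of > 25000 nM in this assay, at which 3 of the 3 values shown sit, holds for every value. The three measured steps, a step that the two limits leave unreadable from compound 1 to compound 2, a step that the two limits leave unreadable from compound 1 to compound 3 and a step that the two limits leave unreadable from compound 2 to compound 3, all change the ring on the nitrogen and cannot be read in size.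

Compound 4, `COc1cccc(/C=C/C(=O)c2sc(Nc3ccc(Cl)c(Cl)c3)nc2C)c1`, changes a different part: 3-methoxyphenyl in place of 4-chlorophenyl on a double-bonded chain carbon bound to a double-bonded chain carbon. Within the data shown here, no measured step touches this position, so nothing shows a direction. Since every measured compound sits at the limit, compound 4 is expected to stay near it as well, with the step that the limit leaves unreadable from compound 3 to compound 4 being a guess only. Compound 4 is estimated at 30000 nM, between 8000 nM and 100000 nM.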

Compound 4, half-maximal inhibitory concentration: > 25000 nM
Compound 4 was reported as a limit; the forecaster's own chance of this, stated with the estimate: 75%; the middle value does not contradict the limit.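

Compound 3 and compound 4 both sit at a limit of the assay, so the change between them cannot be read in size. The compounds shown leave open which change, if any, would give a real number in this assay.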